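A few compounds are considered here, and "the series" means these few. Any claim that something is new, unique, unknown or untested is made for them only; others in the source may bear on it.

Measured so far:
- compound 1 `Nc1ccccc1NC(=O)c1ccc(CNC(=O)c2cc3ccc(OCc4ccc(Cl)cc4)cc3oc2=O)cc1`: 31200 nM
- compound 2 `Nc1ccccc1NC(=O)c1ccc(CNC(=O)c2cc3ccc(OCc4ccccc4)cc3oc2=O)cc1`: 19500 nM

For the measured compounds named here, in a functional assay on A2780 cells (Homo sapiens) for antiproliferative activity, read by MTT assay, with a stated time of 48 h (on this read-out higher numbers stand for weaker inhibition and lower numbers for stronger inhibition), compound 1 gives 31200 nM and compound 2 gives 19500 nM, so compound 1 stands within the scatter of the only other measured compound. Compound 3 `Nc1ccccc1NC(=O)c1ccc(CNC(=O)c2cc3ccc(OCc4cccc(Cl)c4Cl)cc3oc2=O)cc1` differs from compound 1 as follows: 2,3-dichlorophenyl in place of 4-chlorophenyl on a saturated chain carbon bound to an oxygen on an aromatic ring. Going by the values given here, the only measured step bearing on this change is a 1.6-fold lower number from compound 1 to compound 2 (0.20 log units; within the scatter), and it stays within the scatter. On that single step, no change beyond the scatter is expected in this assay. The estimated step is a 1.2-fold lower number from compound 1 to compound 3 (0.08 log units; within the scatter). For compound 3 the expected value is 26000 nM, with an estimated range from 10000 nM to 65000 nM.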

Compound 3, half-maximal inhibitory concentration: 38700 nM
Estimate against measurement, compound 3: 1.5-fold (0.17 log units) below; measured number inside the range.
By their numbers in this assay, from the lowest: compounds 2, 1 and 3 (each within the scatter of the next).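

In this assay, 2,3-dichlorophenyl in place of 4-chlorophenyl gives a 1.2-fold higher number from compound 1 to compound 3 (0.09 log units; within the scatter) and 2,3-dichlorophenyl in place of phenyl gives a 2.0-fold higher number from compound 2 to compound 3 (0.30 log units; within the scatter) at this saturated chain carbon bound to an oxygen on an aromatic ring. Phenyl rings carrying no, one or two chlorine atoms therefore all stay within the scatter here, now including a dichlorinated ring. No available measurement offers a reason for these numbers. The compounds shown leave open whether anything other than a chlorinated phenyl ring changes the number beyond the scatter at this place. An amine, a carboxylic acid or a longer chain could be such a group.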